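Heptyl for methoxy on the N-methyl member of the series

The source may hold more compounds than are shown below. What is called first, only, known or untested is meant among the compounds shown, and "the series" means these compounds.

Measured so far:
compound 1 `CCCCc1ccc(-c2c(C)[nH]c(=O)n2C2CCCCC2)cc1`: 27100 nM
compound 2 `CCCCc1ccc(-c2c(C)[nH]c(=O)n2-c2ccccc2)cc1`: 16600 nM
compound 3 `COc1ccc(-c2c(C)[nH]c(=O)n2C)cc1`: 147000 nM

In a functional assay on brain (Rattus norvegicus, strain Wistar) for inhibition (on this read-out lower numbers stand for stronger inhibition and higher numbers for weaker inhibition), compound 3 gives the highest of the three numbers; compound 1 is nearest and compound 2 furthest, both differences beyond the scatter. Compound 4 `CCCCCCCc1ccc(-c2c(C)[nH]c(=O)n2C)cc1` differs from compound 3 by heptyl in place of methoxy on an aromatic carbon. Within the data shown here, the one measured step, a 1.6-fold lower number from compound 1 to compound 2 (0.21 log units; within the scatter), concerns the aromatic nitrogen and not this position, so nothing measured bears directly on the change. Compounds 1 and 2 carry butyl and give lower numbers than compound 3, but they also differ on the nitrogen. From the compounds shown here alone, how much of that difference comes from the chain is unknown. A lower number is expected for compound 4, with a step of a 3.7-fold lower number from compound 3 to compound 4 (0.57 log units; beyond the scatter). The estimate for compound 4 in this assay is 40000 nM, between 10000 nM and 160000 nM.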

Compound 4, half-maximal inhibitory concentration: 8400 nM
For compound 4 the middle estimate is 4.8-fold (0.68 log units) above the measured one, outside the stated range (below it).
By their numbers in this assay, from the lowest: compounds 4, 2 and 1 (each within the scatter of the next, the first and the last beyond it); then compound 3.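

Heptyl in place of methoxy on this aromatic carbon gives a large change in this assay, with an 18-fold lower number from compound 3 to compound 4 (1.24 log units; beyond the scatter). Unlike the step on the aromatic nitrogen, this step lies beyond the scatter, so the series clearly responds to the group at this position. Nothing available explains the size of the change.

From the compounds shown here alone, it remains open whether a longer chain such as decyl would lower the number further, or whether butyl on the N-methyl member would already capture part of the step. The effect of an amine or a carboxylic acid at the end of the chain is also unknown.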